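Chain extension to a chlorinated urea on a shared core

The source may hold more compounds than are shown below. What is called first, only, known or untested is meant among the compounds shown, and "the series" means these compounds.

Compound 1 `CCCC(=O)Nc1c(C(O)(C(F)(F)F)C(F)(F)F)ccc2ccccc12` is tested in an assay on LtK cells with ATP-sensitive inward rectifier potassium channel 11 (Homo sapiens) as the target (on this read-out lower numbers stand for an effect already at smaller amounts and higher numbers for an effect only at larger amounts of compound), where compound 1 gives 131 nM; among three measured numbers this is the second highest, nearer to compound 3 than to compound 2. Compound 3 `O=C(CC1CCCC1)Nc1c(C(O)(C(F)(F)F)C(F)(F)F)ccc2ccccc12` gives 81 nM, and compound 2 `CCC(CC)C(=O)Nc1c(C(O)(C(F)(F)F)C(F)(F)F)ccc2ccccc12` gives 4340 nM. The step of a 33-fold higher number from compound 1 to compound 2 (1.52 log units; beyond the scatter) is large, whereas a 1.6-fold lower number from compound 1 to compound 3 (0.21 log units; within the scatter) stays within the scatter, and a 54-fold lower number from compound 2 to compound 3 (1.73 log units; beyond the scatter) is again large. Compound 4 `O=C(NCCCCCCCl)Nc1c(C(O)(C(F)(F)F)C(F)(F)F)ccc2ccccc12` differs from compound 1 as follows: (6-chlorohexyl)amino in place of propyl on a carbonyl carbon. Among the compounds with values here, no measured step covers such a change; the measured steps show only that branching on a saturated chain carbon bound to the carbonyl carbon costs much while ring closure does not. Compound 4 is therefore expected to show a modest step, a 1.9-fold higher number from compound 1 to compound 4 (0.28 log units; within the scatter), and its estimated value is 250 nM, between 50 nM and 2000 nM.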

Compound 4, half-maximal effective concentration: 4840 nM
For compound 4 the middle estimate is 19-fold (1.29 log units) below the measured one; the measured number lies above the stated range.
By their numbers in this assay, from the lowest: compounds 3 and 1 (each within the scatter of the next); then compounds 2 and 4 (each within the scatter of the next).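

In this assay the exchange of propyl for (6-chlorohexyl)amino on the carbonyl carbon gives a 37-fold higher number from compound 1 to compound 4 (1.57 log units; beyond the scatter) and the same group in place of cyclopentylmethyl gives a 60-fold higher number from compound 3 to compound 4 (1.78 log units; beyond the scatter) showing that a large step at this position does not require branching. Against the branched chain of compound 2 the urea gives a 1.1-fold higher number from compound 2 to compound 4 (0.05 log units; within the scatter) so two different groups on the carbonyl carbon arrive at numbers within the scatter of each other. Nothing at hand explains the large steps.

The compounds shown leave open whether the step follows the urea nitrogen, the chain length or the chlorine. Propylamino, hexylamino and 6-chlorohexyl on the same carbonyl carbon would separate these three.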